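The source may report more compounds than this note shows. Statements on the series, on what has been measured and on what is new or still open speak of the compounds shown alone.

Compound 1 `CC(C)CNC(=C\C(=O)/C=C/c1ccc(O)cc1)/C=C/c1ccc(O)cc1` and compound 2 `CCC(C)NC(=C\C(=O)/C=C/c1ccc(O)cc1)/C=C/c1ccc(O)cc1` share one core and differ only in the group on an amine nitrogen, isobutyl in compound 1 and sec-butyl in compound 2. In a functional assay on CHO-K1 cells (Cricetulus griseus) for inhibition, read by sulforhodamine B assay, with a stated time of 72 h (a lower number here means a stronger inhibitor, a higher number a weaker inhibitor), compound 1 gives 23700 nM. In this assay compound 2 gives 15100 nM, so the two numbers cannot be told apart. Compound 3 `O=C(/C=C(/C=C/c1ccc(O)cc1)NC1CCCCC1)/C=C/c1ccc(O)cc1` has cyclohexyl in place of sec-butyl on an amine nitrogen. Going by the values given here, the only measured guide is a 1.6-fold lower number from compound 1 to compound 2 (0.20 log units; within the scatter). Among the compounds with values here, that step swapped one open chain for another, and no compound with a ring at this nitrogen has been measured yet. No step beyond the scatter is therefore expected in this assay. The expected change is a 1.1-fold lower number from compound 2 to compound 3 (0.03 log units; within the scatter). For compound 3 the estimated value is 14000 nM, with an expected range of 6000 nM to 32000 nM.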

Compound 3, half-maximal inhibitory concentration: 11600 nM
For compound 3 the middle estimate is 1.2-fold (0.08 log units) above the measured one; measured number inside the range.
By their numbers in this assay, from the lowest: compounds 3, 2 and 1 (each within the scatter of the next, the first and the last beyond it).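

In this assay a ring on the amine nitrogen does about as well as an open chain: cyclohexyl in place of sec-butyl gives a 1.3-fold lower number from compound 2 to compound 3 (0.11 log units; within the scatter) and so no real change. Cyclohexyl in place of isobutyl gives a 2.0-fold lower number from compound 1 to compound 3 (0.31 log units; beyond the scatter), the only step among these compounds that passes the scatter, and only modestly. Nothing measured here explains that step, so it stands as an observation alone.

From the compounds shown here alone, it remains open whether a smaller ring such as cyclopropyl, or a ring carrying oxygen such as tetrahydropyranyl, would fit this pattern on the nitrogen. An aromatic group such as phenyl or benzyl, or a longer chain such as n-octyl, could also move the number further than these groups do, or not at all.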